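Benzimidazole Piperazine Amides: Aryl Carbonyl Lowers Inhibition

The compounds below may be only part of what the source reports. "The series", "measured", "known", "first", "only" and "open" are said of these compounds alone.

Compound 3 `CCC(=O)N1CCN(Cc2nc3ccccc3n2Cc2cccc(C)c2)CC1` gives the highest value among the three measured compounds in an assay on isolated protein for inhibition of aldehyde dehydrogenase 1A1 (Homo sapiens), read by spectrophotometry, tested at 10 uM (on this read-out higher numbers stand for more inhibition at the one concentration tested (going by the name of the read-out) and lower numbers for less inhibition), namely 85.1%. Compound 1 `CC(=O)N1CCN(Cc2nc3ccccc3n2Cc2cccc(C)c2)CC1` gives 70.3%, and compound 2 `Cc1cccc(Cn2c(CN3CCN(C(=O)c4ccc(C#N)cc4)CC3)nc3ccccc32)c1` gives 20.8%. Compound 4 `COc1ccc(C(=O)N2CCN(Cc3nc4ccccc4n3Cc3cccc(C)c3)CC2)cc1` differs from compound 3 by 4-methoxyphenyl in place of ethyl on a carbonyl carbon. Among the measured compounds shown here, two measured steps bear on it: the aryl carbonyl step a number 49.5 percentage points lower from compound 1 to compound 2 (beyond the scatter), and the reverse a number 64.3 percentage points higher from compound 2 to compound 3 (beyond the scatter), both large. A large drop is therefore expected for the step of a number 55.1 percentage points lower from compound 3 to compound 4 (beyond the scatter), since compound 4 carries an aryl group on its carbonyl carbon as compound 2 does, whose value is 20.8%. For compound 4 the estimate in this assay is 30%, with a range from 10% to 60%.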

Compound 4, a percentage reported as inhibition, at one concentration (the size of the read-out at that concentration, not a potency): 55.5%
For compound 4 the middle estimate is 25.5 percentage points below the measured one, within the range that was stated.
By their numbers in this assay, from the lowest: compound 2; then compound 4; then compound 1; then compound 3.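

In this assay the 4-methoxyphenyl group on the carbonyl carbon still costs inhibition, with a number 29.6 percentage points lower from compound 3 to compound 4 (beyond the scatter) and a number 14.8 percentage points lower from compound 1 to compound 4 (beyond the scatter) as the steps from the two small acyl compounds. Yet methoxy in place of cyano on an aromatic carbon gives a number 34.7 percentage points higher from compound 2 to compound 4 (beyond the scatter) so the outcome at this position depends on the group the aryl ring carries, not on the ring alone. Nothing available explains this difference.

On these data alone, it remains open how an unsubstituted phenyl, or a phenyl bearing an amine or a carboxylic acid, would compare. Whether a chain longer than ethyl would add to the inhibition is also unresolved.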